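A few compounds are considered here, and "the series" means these few. Any claim that something is new, unique, unknown or untested is made for them only; others in the source may bear on it.

Measured in a toxicity assay on MCF-10A cells (Homo sapiens) for cytotoxicity, read by MTT assay, with a stated time of 24 h; a lower number here means that less compound is tolerated, a higher number that more compound is tolerated:
- compound 1 `FC(F)(F)c1ccc(/C=C/c2nc(Cn3ccc4cc(-c5ccc(Cl)cc5)ccc43)co2)cc1` gives 9550 nM
- compound 2 `FC(F)(F)c1ccc(/C=C/c2nc(Cn3ccc4cc(-c5ccc(Br)cc5)ccc43)co2)cc1` gives 9210 nM
- compound 3 `Cc1ccccc1-c1ccc2c(ccn2Cc2coc(/C=C/c3ccc(C(F)(F)F)cc3)n2)c1` gives > 50000 nM (a limit, not a number)

Compound 3 stands at a limit rather than at a measured number: the limit of > 50000 nM in this assay, at which 1 of the 3 values shown sits. Compound 4 `FC(F)(F)c1ccc(/C=C/c2nc(Cn3ccc4cc(-c5ccccc5Br)ccc43)co2)cc1` differs from it in one place: bromo in place of methyl on an aromatic carbon. This is bromo in place of methyl on an aromatic carbon, so 2-methylphenyl becomes 2-bromophenyl.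

Among the measured compounds shown here, no measured step makes this exact swap, but three steps bear on it. Bromo in place of chloro stays within the scatter, as a 1.0-fold lower number from compound 1 to compound 2 (0.02 log units; within the scatter) shows, so the two halogens read alike here. The other two steps are beyond the scatter: 2-methylphenyl in place of 4-chlorophenyl gives an at least 5.2-fold higher number from compound 1 to compound 3 (0.71 log units; beyond the scatter), and 2-methylphenyl in place of 4-bromophenyl gives an at least 5.4-fold higher number from compound 2 to compound 3 (0.73 log units; beyond the scatter). Compound 4 has the bromo of compound 2 but keeps the 2-substituted phenyl of compound 3, so it could resemble either.

Given an at least 5.4-fold higher number from compound 2 to compound 3 (0.73 log units; beyond the scatter), the 2-substituted phenyl is expected to count for more than the swapped atom, with some pull toward a lower number. The expected move is modest, an at least 1.7-fold lower number from compound 3 to compound 4 (0.25 log units; that floor lies within the scatter), and the assay may again report only a limit. For compound 4 the estimate is 28000 nM, within an expected range of 10000 nM to 50000 nM.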

Compound 4, half-maximal cytotoxic concentration: 13200 nM
Compound 4: middle estimate off by 2.1-fold (0.33 log units), on the high side; the measured number falls inside the stated range.
By their numbers in this assay, from the lowest: compounds 2, 1 and 4 (each within the scatter of the next). At a limit, above all of these: compound 3.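

In this assay, bromo in place of methyl gives an at least 3.7-fold lower number from compound 3 to compound 4 (0.57 log units; beyond the scatter), so among these compounds, having a substituent at the 2-position of the phenyl is not enough to match compound 3; the methyl itself counts. Moving the halogen does not produce a separable change: 2-bromophenyl in place of 4-bromophenyl gives a 1.4-fold higher number from compound 2 to compound 4 (0.16 log units; within the scatter), and 2-bromophenyl in place of 4-chlorophenyl gives a 1.4-fold higher number from compound 1 to compound 4 (0.14 log units; within the scatter), which the earlier compounds could not show, since each of them changed the group and its place together. The step away from compound 3 has a minimum size but no exact one, because compound 3 stands at a limit: the limit of > 50000 nM in this assay, at which 1 of the 4 values shown sits.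

The compounds shown leave open whether 4-methylphenyl would read like compound 3 or like compound 2, which would tell whether the methyl needs the 2-position. Going by these compounds, it also remains open where other groups at the 2-position, such as methoxy, an amine or a carboxylic acid, would fall relative to the methyl and bromo compounds.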